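Turning one stereocentre in a propyl-phenyl urea

A few compounds are considered here, and "the series" means these few. Any claim that something is new, unique, unknown or untested is made for them only; others in the source may bear on it.

Measured so far:
compound 1, `CCc1ccc(NC(=O)N[C@@H](C)c2ccccc2)cc1`, 95%
compound 2, `CCCc1ccc(NC(=O)N[C@H](C)c2ccccc2)cc1`, 31%

Both compounds were tested in an ADME assay on the whole organism with Oryza sativa as the target, tested at 1 uM; a higher number here means a weaker effect of the compound at the concentration tested, a lower number a stronger effect. Compound 1 gives 95%, while compound 2 gives 31%, the lowest of the two numbers, and the gap between the two lies beyond the usual scatter, so compound 2 shows the stronger effect on the plant at the concentration tested.

The next compound is compound 3, `CCCc1ccc(NC(=O)N[C@@H](C)c2ccccc2)cc1`. Compared with compound 2, (the two compounds have the same atoms and bonds and differ only in configuration as drawn: 1 of 1 stereo elements differ; a stereocentre at a saturated chain carbon is drawn R in compound 2 and S in compound 3). Compound 2 and compound 3 are thus mirror images of each other, built from the same atoms joined in the same way.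

Going by the values given here, no step between two compounds that differ only in configuration has been measured, so the size of this step is not known. At its stereocentre compound 3 carries the same drawn configuration as compound 1, and compound 1 gives 95%, a weak effect. On that slim basis a step upward from compound 2, beyond the scatter, is expected as a number 34 percentage points higher from compound 2 to compound 3 (beyond the scatter). Compound 3 is therefore estimated at 65%, within 25% to 95%.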

Compound 3, a percentage reported as activity, at one concentration (the size of the read-out at that concentration, not a potency): 76%
For compound 3 the middle estimate is 11 percentage points below the measured one; measured number inside the range.
By their numbers in this assay, from the lowest: compound 2; then compound 3; then compound 1.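

Turning the single stereocentre from R as drawn to S as drawn gives, in this assay, a number 45 percentage points higher from compound 2 to compound 3 (beyond the scatter), a large step, so the effect on the plant at this concentration depends on the configuration at this saturated chain carbon, and the cause of the gap can be narrowed to that one feature: the fact that compounds 2 and 3 differ only in the configuration as drawn. The earlier pair could not show this, since compound 1 and compound 2 differ in both the chain and the configuration. With the configuration held at S as drawn, methyl in place of hydrogen on a saturated chain carbon, two bonds along the chain from an aromatic carbon, gives a number 19 percentage points lower from compound 1 to compound 3 (beyond the scatter), a modest step beside the large one, so the chain also matters here, though by a smaller step than the stereocentre.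

Still open, going by these compounds, is whether the R form keeps its stronger effect when the chain is the shorter one of compound 1, or when a longer chain such as butyl takes the place of propyl. Also open, on these data alone, is what happens with a group of another kind at that place, such as an amine or a carboxylic acid.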